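Carboxy on the phenylsulfonyl group of compound 2

A few compounds are considered here, and "the series" means these few. Any claim that something is new, unique, unknown or untested is made for them only; others in the source may bear on it.

Values in a functional assay for inhibition, with Homo sapiens as the target; a higher number here means a weaker inhibitor, a lower number a stronger inhibitor:
compound 1 `CS(=O)(=O)N[C@@H](CNC(=O)c1ccc2c(c1)C(=O)N(CCC1CCNCC1)C2)C(=O)O`: 14 nM
compound 2 `O=C(NC[C@H](NS(=O)(=O)c1ccccc1)C(=O)O)c1ccc2c(c1)C(=O)N(CCC1CCNCC1)C2`: 8 nM

Within the data shown here, with only two numbers, compound 2 at 8 nM stands level with compound 1, the two lying within the scatter of each other. Compound 3 `O=C(NC[C@H](NS(=O)(=O)c1ccccc1C(=O)O)C(=O)O)c1ccc2c(c1)C(=O)N(CCC1CCNCC1)C2` differs from compound 2 only on the aryl group of the sulfonyl, which goes from phenyl to 2-carboxyphenyl (carboxy in place of hydrogen on an aromatic carbon). Among the measured compounds shown here, the one measured step at this sulfonyl sulfur, phenyl in place of methyl, is a 1.8-fold lower number from compound 1 to compound 2 (0.24 log units; within the scatter) and stays within the scatter. For the measured compounds named here, no measured compound carries a carboxy on this ring, so that step is only a loose guide. Resting on it, a similarly small step is expected in this assay, leaning slightly towards a higher number. The estimate means a 1.5-fold higher number from compound 2 to compound 3 (0.18 log units; within the scatter), an expected move of modest size. Compound 3 is estimated at 12 nM, with an expected range from 4 nM to 36 nM.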

Compound 3, half-maximal inhibitory concentration: 15 nM
Compound 3: middle estimate off by 1.3-fold (0.10 log units), on the low side, within the range that was stated.
By their numbers in this assay, from the lowest: compounds 2, 1 and 3 (each within the scatter of the next).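

In this assay carboxy in place of hydrogen on an aromatic carbon of the phenylsulfonyl group gives a 1.9-fold higher number from compound 2 to compound 3 (0.27 log units; within the scatter) and so stays within the scatter. Measured against the methyl on the sulfonyl sulfur, 2-carboxyphenyl gives a 1.1-fold higher number from compound 1 to compound 3 (0.03 log units; within the scatter) and also stays within the scatter, so methyl, phenyl and 2-carboxyphenyl on this sulfur all read alike in this assay. No evidence on hand bears on this result.

From the compounds shown here alone, whether any group on this ring can move the number beyond the scatter remains open, since all three steps at this sulfonyl sulfur lie within it. A methyl ester or an aminomethyl group in place of the carboxy would show whether the reading depends on the carboxy itself or holds for other groups on this ring.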